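Leucine boronic acid dipeptides: amine N-methyl to hydrogen

A few compounds are considered here, and "the series" means these few. Any claim that something is new, unique, unknown or untested is made for them only; others in the source may bear on it.

Measured compounds:
compound 1 `CNCC(=O)N[C@@H](CC(C)C)B(O)O` 160 nM
compound 2 `CC[C@H](N)C(=O)N[C@@H](CC(C)C)B(O)O` 1500 nM
compound 3 `CC(C)C[C@H](NC(=O)[C@H](C)N)B(O)O` 3200 nM

In an ADME assay on FSCLL cells (Homo sapiens) for cytotoxicity, read by MTT assay, with a stated time of 24 h (on this read-out higher numbers stand for lower toxicity in this test and lower numbers for higher toxicity in this test), compound 1 sits at the lowest number of the three; the nearest is compound 2 with a step of a 9.4-fold higher number from compound 1 to compound 2 (0.97 log units; beyond the scatter), the furthest compound 3 with a 20-fold higher number from compound 1 to compound 3 (1.30 log units; beyond the scatter). Compound 4 `CC(C)C[C@H](NC(=O)CN)B(O)O` has not yet been measured. It differs from compound 1 by hydrogen in place of methyl on an amine nitrogen, so the (methylamino)methyl on the carbonyl carbon becomes aminomethyl.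

For the measured compounds named here, no measured step isolates this change. The two steps from compound 1 each replace the (methylamino)methyl with a primary-amine group bearing an alkyl on the chain carbon, and both moved the number upward by a modest to large amount. The step of a 2.1-fold higher number from compound 2 to compound 3 (0.33 log units; beyond the scatter) removes a methyl from a saturated chain carbon and also raises the number, modestly. All three measured steps point the same way, with the primary amines of compound 2 and compound 3 above compound 1, but none matches the change to compound 4 exactly.

The expectation for compound 4 in this assay is therefore a modest upward step, a 3.8-fold higher number from compound 1 to compound 4 (0.57 log units; beyond the scatter), estimated at 600 nM with a range of 200 nM to 2000 nM.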

Compound 4, half-maximal cytotoxic concentration: 670 nM
Compound 4: middle estimate off by 1.1-fold (0.05 log units), on the low side, within the range that was stated.
By their numbers in this assay, from the lowest: compound 1; then compound 4; then compound 2; then compound 3.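

In this assay the change is now seen alone: a 4.2-fold higher number from compound 1 to compound 4 (0.62 log units; beyond the scatter) shows that hydrogen in place of methyl on an amine nitrogen is enough by itself to raise the number, so lower toxicity in this test follows from that single replacement, with no change on the chain carbon. With the amine held primary, the saturated chain carbon bound to an amine nitrogen and a carbonyl carbon also matters, as a 4.8-fold lower number from compound 3 to compound 4 (0.68 log units; beyond the scatter) and a 2.2-fold lower number from compound 2 to compound 4 (0.35 log units; beyond the scatter) both put compound 4 below its alkyl-bearing partners, and the order of hydrogen, then ethyl, then methyl does not follow chain length, since compound 3 with the methyl stands above compound 2 with the ethyl. The data shown give no measurement that could explain either shift.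

Open, going by these compounds, is whether the trend on the amine nitrogen continues beyond methyl, for example with an ethyl or a second methyl on that nitrogen in place of the methylamino group. Also open, on these data alone, is how a longer chain such as propyl, or a hydroxymethyl, on the saturated chain carbon would sit relative to the methyl and ethyl, and whether a methyl on the amine nitrogen of compound 2 or compound 3 would have the same effect there.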